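The compounds below may be only part of what the source reports. "The series", "measured", "known", "first", "only" and "open" are said of these compounds alone.

Compound 1 `COc1cc(C=C(C(=O)/C=C/c2cccc(OC)c2OC)C(=O)/C=C/c2cccc(OC)c2OC)ccc1O` and compound 2 `COc1cccc(/C=C/C(=O)C(=Cc2ccc(O)c(F)c2)C(=O)/C=C/c2cccc(OC)c2OC)c1OC` share one core and differ in a single spot. In a functional assay on HepG2 cells (Homo sapiens) for antiproliferative activity, read by sulforhodamine B assay, with a stated time of 48 h (on this read-out higher numbers stand for weaker inhibition and lower numbers for stronger inhibition), compound 1 gives 200 nM and compound 2 gives 220 nM. The change between them is fluoro in place of methoxy on an aromatic carbon, and it made a 1.1-fold higher number from compound 1 to compound 2 (0.04 log units; within the scatter). So swapping these two groups on this core left the read-out essentially where it was.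

Compound 3 `COc1cc(OC)c(/C=C/C(=O)C(=Cc2ccc(O)c(OC)c2)C(=O)/C=C/c2c(OC)cc(OC)cc2OC)c(OC)c1` is built on a different core; the difference between the two cores is not broken down here. In this assay compound 3 gives 670 nM, the highest of the three numbers seen so far, and its distance from compound 2 and from compound 1 lies beyond the usual scatter of repeated measurements.

Compound 4 `COc1cc(OC)c(/C=C/C(=O)C(=Cc2ccc(O)c(F)c2)C(=O)/C=C/c2c(OC)cc(OC)cc2OC)c(OC)c1` has not yet been measured. It differs from compound 3 by fluoro in place of methoxy on an aromatic carbon. The surroundings of this change read the same, word for word, as for the earlier pair, so this is the same change and not merely the same kind of change. Going by the values given here, with only one prior example to rest on, the expectation is that this change again produces no step worth noting: the estimated step is a 1.1-fold higher number from compound 3 to compound 4 (0.03 log units; within the scatter), resting on compound 1 and compound 2, whose step was a 1.1-fold higher number from compound 1 to compound 2 (0.04 log units; within the scatter). On that basis compound 4 is expected to give 720 nM in this assay, with a plausible range from 400 nM to 1300 nM.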

Compound 4, half-maximal inhibitory concentration: 810 nM
Compound 4: the middle estimate sits 1.1-fold (0.05 log units) below what was measured; measured number inside the range.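

In this assay, putting fluoro in place of the methoxy, which turns the 4-hydroxy-3-methoxyphenyl group into 3-fluoro-4-hydroxyphenyl, gave a 1.2-fold higher number from compound 3 to compound 4 (0.08 log units; within the scatter), so on this second core the swap again left the read-out essentially where it was. Set side by side, the two steps cannot be told apart, which means the change carried over from one core to the other without any visible difference: the same change on two cores in this assay, a 1.1-fold higher number (0.04 log units; within the scatter) from compound 1 to compound 2 and a 1.2-fold higher number (0.08 log units; within the scatter) from compound 3 to compound 4, 1.1-fold (0.04 log units) apart, within the scatter of two such steps. This shows that, for these two cores and this one assay, the methoxy and the fluoro can stand in for each other with little consequence for the number, but it does not show that the same holds on every core in the series, and it does not explain why the two groups give such similar results.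

The compounds shown leave open whether other groups at this spot, ortho to the hydroxy group, such as chloro, an amine or a longer chain like ethoxy, would also leave the number in place. They also leave open whether the swap would stay as quiet if the hydroxy group itself gave way to a methoxy group.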